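Changing the Aryl Group on the Triazole Nitrogen

The compounds below may be only part of what the source reports. "The series", "measured", "known", "first", "only" and "open" are said of these compounds alone.

Measured compounds:
Compound 1, `CCc1ccccc1-n1nncc1CN1C(=O)C2(C(C#N)=C(N)Oc3c(N)cc4nc5ccccc5nc4c32)c2ccccc21`, gives 24600 nM in a functional assay on A549 cells (Homo sapiens) for antiproliferative activity, read by MTT assay, with a stated time of 48 h; a lower number here means a stronger inhibitor, a higher number a weaker inhibitor.
Compound 2, `CCc1cccc(CC)c1-n1nncc1CN1C(=O)C2(C(C#N)=C(N)Oc3c(N)cc4nc5ccccc5nc4c32)c2ccccc21`, gives only a limit in this assay, > 50000 nM, so compound 2 sits at the limit of > 50000 nM in this assay, at which 1 of the 2 values shown sits.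

Within the data shown here, the one measured step, an at least 2.0-fold higher number from compound 1 to compound 2 (0.30 log units; that floor lies within the scatter), adds an ethyl and reaches that limit. Compound 3, `COc1ccc(OC)c(-n2nncc2CN2C(=O)C3(C(C#N)=C(N)Oc4c(N)cc5nc6ccccc6nc5c43)c3ccccc32)c1`, differs from compound 2 by 2,5-dimethoxyphenyl in place of 2,6-diethylphenyl on an aromatic nitrogen. Among the measured compounds shown here, no measured step covers a methoxy group, so the direction is open; removing both ethyls leans toward the number of compound 1. Compound 3 is therefore estimated at 35000 nM, range 12000 nM to 100000 nM, an expected step of an at least 1.4-fold lower number from compound 2 to compound 3 (0.15 log units; that floor lies within the scatter).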

Compound 3, half-maximal inhibitory concentration: 28100 nM
Beside the measured number, compound 3's estimate is 1.2-fold (0.10 log units) above it; low and high end bracket the measured number.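

Swapping 2-ethylphenyl for 2,5-dimethoxyphenyl on this aromatic nitrogen gives a 1.1-fold higher number from compound 1 to compound 3 (0.06 log units; within the scatter) in this assay, so two methoxy groups on the aryl ring read the same as one ethyl. The other step, an at least 1.7-fold lower number from compound 2 to compound 3 (0.25 log units; that floor lies within the scatter), is only a floor, because compound 2 is a limit and not a number: the limit of > 50000 nM in this assay, at which 1 of the 3 values shown sits.

Still open, from the compounds shown here alone, is what a single methoxy group would give on this ring. So is whether an amine or a carboxylic acid there would move the number beyond the scatter.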